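The source may hold more compounds than are shown below. What is called first, only, known or untested is meant among the compounds shown, and "the series" means these compounds.

Measured so far in an ADME assay on L6 cells (Rattus norvegicus) for cytotoxicity; a lower number here means a stronger inhibitor, a higher number a weaker inhibitor:
compound 1 `O=C(NCCCN1CCN(CCCNc2ccnc3cc(Cl)ccc23)CC1)c1cccc(C(F)(F)F)c1`: 30100 nM
compound 2 `CCOc1ccc(C(=O)NCCCN2CCN(CCCNc3ccnc4cc(Cl)ccc34)CC2)cc1`: 5300 nM
compound 3 `O=C(CCCc1ccccc1)NCCCN1CCN(CCCNc2ccnc3cc(Cl)ccc23)CC1`: 11000 nM

Compound 1 stands at the highest number of the three, so it is the weakest inhibitor of this set. Both steps away from it run downward and beyond the scatter: a 5.7-fold lower number from compound 1 to compound 2 (0.75 log units; beyond the scatter) and a 2.7-fold lower number from compound 1 to compound 3 (0.44 log units; beyond the scatter). Compound 4 `O=C(NCCCN1CCN(CCCNc2ccnc3cc(Cl)ccc23)CC1)c1cc(F)cc(F)c1` keeps the shared core of compound 1 and alters only the group on the carbonyl carbon: 3,5-difluorophenyl in place of 3-(trifluoromethyl)phenyl on a carbonyl carbon. Neither measured step tests this exact change; both replaced the same group with something of a different kind and gave modest lowerings in this assay, so a downward step is expected here too, though smaller, likely near the scatter: a 1.5-fold lower number from compound 1 to compound 4 (0.18 log units; within the scatter). Compound 4 is thus estimated at 20000 nM, within 8000 nM to 50000 nM.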

Compound 4, half-maximal inhibitory concentration: 11600 nM
The estimate for compound 4 lay 1.7-fold (0.24 log units) above the measured number; the range from low to high includes it.
By their numbers in this assay, from the lowest: compound 2; then compounds 3 and 4 (each within the scatter of the next); then compound 1.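

On the carbonyl carbon, a phenyl ring carrying only fluorines also lowers the number relative to 3-(trifluoromethyl)phenyl (a 2.6-fold lower number from compound 1 to compound 4 (0.41 log units; beyond the scatter)), so this lowering does not depend on an ethoxy group or a chain. The 3,5-difluorophenyl cannot be told apart from the 3-phenylpropyl (a 1.1-fold higher number from compound 3 to compound 4 (0.02 log units; within the scatter)), yet it stays short of the 4-ethoxyphenyl (a 2.2-fold higher number from compound 2 to compound 4 (0.34 log units; beyond the scatter)). Nothing available explains these differences.

Open, from the compounds shown here alone, is whether an unsubstituted phenyl, a single fluorine or a methoxy group would shift the number. Going by these compounds, an amine or carboxylic acid on the ring, or a chain longer than 3-phenylpropyl, also remains untested in these data.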